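Working notes: from compound 3 to compound 4

A few compounds are considered here, and "the series" means these few. Any claim that something is new, unique, unknown or untested is made for them only; others in the source may bear on it.

compound 1 `O=C(C=C1CCN(C(=O)c2ccc(F)cc2)CC1)N[C@@H]1CCN(Cc2ccc3cc(F)ccc3c2)C1`: 237 mL/min/kg
compound 2 `COc1ccc(C(=O)N2CCC(=CC(=O)N[C@@H]3CCN(Cc4ccc5cc(F)ccc5c4)C3)CC2)cc1`: 252 mL/min/kg
compound 3 `COc1cccc(C(=O)N2CCC(=CC(=O)N[C@@H]3CCN(Cc4ccc5cc(F)ccc5c4)C3)CC2)c1`: 500 mL/min/kg

All three numbers come from an in vitro ADME assay on microsomes from liver (Homo sapiens) for metabolic stability; a higher number here means faster removal of the compound, a lower number slower removal. Going by the values given here, compound 3, at 500 mL/min/kg, stands clear of only one neighbour: the series shows a 2.1-fold higher number from compound 1 to compound 3 (0.32 log units; beyond the scatter), whereas it shows a 2.0-fold higher number from compound 2 to compound 3 (0.30 log units; within the scatter). The remaining pair gives a 1.1-fold higher number from compound 1 to compound 2 (0.03 log units; within the scatter).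

The next compound is compound 4 `O=C(C=C1CCN(C(=O)c2ccccc2O)CC1)N[C@@H]1CCN(Cc2ccc3cc(F)ccc3c2)C1`, which carries 2-hydroxyphenyl in place of 3-methoxyphenyl on a carbonyl carbon. The counted difference reads (2-hydroxyphenyl in place of 3-methoxyphenyl on a carbonyl carbon).

Among the compounds with values here, no measured compound carries 2-hydroxyphenyl, so no step speaks to this change directly. The nearest evidence is the set of changes at the same carbonyl carbon, and the largest of them is a 2.1-fold higher number from compound 1 to compound 3 (0.32 log units; beyond the scatter). Within the data shown here, compound 3 is also the only measured compound with 3-methoxyphenyl, so leaving that group is expected to bring the number towards those of compound 1 and compound 2, with low confidence in the direction. The expected change is a 1.9-fold lower number from compound 3 to compound 4 (0.28 log units; within the scatter), a small step that may not clear the scatter. For compound 4 the estimated value in this assay is 260 mL/min/kg, with an expected range from 120 mL/min/kg to 520 mL/min/kg.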

Compound 4, clearance: < 64 mL/min/kg
Compound 4 ended at the assay's limit; the forecaster's own chance of this, stated with the estimate: 5%; at least 4.0-fold (0.60 log units) between middle value and limit.
By their numbers in this assay, from the lowest: compounds 1, 2 and 3 (each within the scatter of the next, the first and the last beyond it). At a limit, below all of these: compound 4.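

Until now, changes at this carbonyl carbon had moved the number in this assay only modestly, the largest being a 2.1-fold higher number from compound 1 to compound 3 (0.32 log units; beyond the scatter); 2-hydroxyphenyl, which counts 1 hydrogen-bond donor where 3-methoxyphenyl counts 0, gives a much larger step, with an at least 7.8-fold lower number from compound 3 to compound 4 (0.89 log units; beyond the scatter). The shift does not come only from leaving 3-methoxyphenyl, since the series also shows an at least 3.9-fold lower number from compound 2 to compound 4 (0.59 log units; beyond the scatter) and an at least 3.7-fold lower number from compound 1 to compound 4 (0.56 log units; beyond the scatter), so 2-hydroxyphenyl stands apart from all three aryl groups measured before it at this position. Compound 4 gave a limit of the assay rather than a number, so all three steps give only the smallest size the change can have: the limit of < 64 mL/min/kg in this assay, at which 1 of the 4 values shown sits.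

The compounds shown do not separate the hydroxy group itself from its place on the ring, and they offer no comparison with an amine or a carboxylic acid on the same phenyl ring. From the compounds shown here alone, how far compound 4 lies past the limit also stays open, as does whether the slower removal seen in this assay holds in any other measure of clearance.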